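The source may hold more compounds than are shown below. What is called first, only, known or untested is meant among the compounds shown, and "the series" means these compounds.

Among the measured compounds shown here, compound 2 `Nc1nc(O)c2nnn([C@H]3CCC[C@H]3CO)c2n1` gives 86700 nM in a functional assay on CCRF-CEM cells (Homo sapiens) for antiproliferative activity (on this read-out higher numbers stand for weaker inhibition and lower numbers for stronger inhibition), the larger of the two numbers measured so far, though the gap to its only neighbour is within the scatter: compound 1 `Nc1nc(Cl)c2nnn([C@H]3CCC[C@H]3CO)c2n1` gives 53000 nM in this assay, and the step of a 1.6-fold higher number from compound 1 to compound 2 (0.21 log units; within the scatter) is within the scatter. Compound 3 `Nc1nc(N)c2nnn([C@H]3CCC[C@H]3CO)c2n1` differs from compound 2 by amino in place of hydroxy on an aromatic carbon. For the measured compounds named here, the one measured step on this aromatic carbon, a 1.6-fold higher number from compound 1 to compound 2 (0.21 log units; within the scatter), showed no shift beyond the scatter, so none is expected here either; the expected step is a 1.3-fold lower number from compound 2 to compound 3 (0.13 log units; within the scatter). Compound 3 is estimated at 65000 nM, within 18000 nM to 240000 nM.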

Compound 3, half-maximal inhibitory concentration: 90500 nM
Compound 3: the middle estimate sits 1.4-fold (0.14 log units) below what was measured; the measured number falls inside the stated range.
By their numbers in this assay, from the lowest: compounds 1, 2 and 3 (each within the scatter of the next).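

Amino in place of hydroxy gives a 1.0-fold higher number from compound 2 to compound 3 (0.02 log units; within the scatter), and amino in place of chloro gives a 1.7-fold higher number from compound 1 to compound 3 (0.23 log units; within the scatter). Chloro, hydroxy and amino on this aromatic carbon, opposite the ring nitrogen, therefore all lie within the scatter of one another on the shared core. Nothing available offers a reason for this absence of a shift.

Going by these compounds, whether a methoxy group, a methylthio group or a phenyl ring on this carbon would shift the number remains open. On these data alone, whether the same flat result would hold on another core is also open.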